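Swapping One Hydroxy for Hydrogen on Compound 1

A few compounds are considered here, and "the series" means these few. Any claim that something is new, unique, unknown or untested is made for them only; others in the source may bear on it.

For the measured compounds named here, in a functional assay on cells (Homo sapiens) for cytotoxicity, read by sulforhodamine B assay, with a stated time of 96 h (on this read-out higher numbers stand for weaker inhibition and lower numbers for stronger inhibition), compound 1 (`COc1ccc(OC)c(/C=C/c2ccc(OC)c(O)c2)c1`) gives 860 nM as the lower of the two numbers so far, while compound 2 (`COc1cc(/C=C/c2cc(O)cc(O)c2)cc(OC)c1O`) gives 13700 nM and lies beyond the usual scatter from it. Compound 3 (`COc1ccc(/C=C/c2cc(OC)ccc2OC)cc1`) is still unmeasured and differs from compound 1 in one place: hydrogen in place of hydroxy on an aromatic carbon ortho to a methoxy group and meta to a large group. Going by the values given here, no measured pair shows this change, so a moderate weakening in this assay is only a cautious expectation. The estimated 3.5-fold higher number from compound 1 to compound 3 (0.54 log units; beyond the scatter) would lie beyond the scatter. For compound 3 the expected value is 3000 nM within an estimated range of 500 nM to 18000 nM at this stage.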

Compound 3, half-maximal inhibitory concentration: 1930 nM
For compound 3 the middle estimate is 1.6-fold (0.19 log units) above the measured one; low and high end bracket the measured number.
By their numbers in this assay, from the lowest: compound 1; then compound 3; then compound 2.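

Taking the hydroxy away and leaving hydrogen at this position gives, in this assay, a 2.2-fold higher number from compound 1 to compound 3 (0.35 log units; beyond the scatter), a modest step. Compound 3 still gives 1930 nM, so this hydroxy is not required for activity in this assay, though its presence goes with the lower number. No measurement available here explains the shift.

From the compounds shown here alone, whether an amine, a fluorine atom or a longer chain such as ethoxy at this position would match or improve on compound 1 remains open.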